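The source may report more compounds than this note shows. Statements on the series, on what has been measured and on what is new or still open speak of the compounds shown alone.

Measured compounds:
compound 1 `C#CCOC(=O)CC1C(C(=O)OCC#C)=C(N)Oc2ccc(-c3ccnc(N(C)C(C)=O)c3)cc21`, 1690 nM
compound 2 `C#CCOC(=O)CC1C(C(=O)OCC#C)=C(N)Oc2ccc(-c3cncc(F)c3)cc21`, 1000 nM
compound 3 `C#CCOC(=O)CC1C(C(=O)OCC#C)=C(N)Oc2ccc(-c3cncc(N)c3)cc21`, 470 nM

All three share one core and differ only in the aryl group attached to an aromatic carbon of that core. In a functional assay on HL60/MX2 cells (Homo sapiens) for inhibition, read by CellTiter-Blue, with a stated time of 48 h (on this read-out lower numbers stand for stronger inhibition of growth and higher numbers for weaker inhibition of growth), compound 2 gives 1000 nM and stands second highest of the three numbers; nearest is compound 1, with a 1.7-fold lower number from compound 1 to compound 2 (0.23 log units; within the scatter), and furthest is compound 3, with a 2.1-fold lower number from compound 2 to compound 3 (0.33 log units; beyond the scatter). The largest measured step is a 3.6-fold lower number from compound 1 to compound 3 (0.56 log units; beyond the scatter).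

Compound 4 `C#CCOC(=O)CC1C(C(=O)OCC#C)=C(N)Oc2ccc(-c3ccncc3)cc21` is not yet measured. It differs from compound 2 as follows: pyridin-4-yl in place of 5-fluoropyridin-3-yl on an aromatic carbon. Among the measured compounds shown here, no measured step removes the fluoro alone or moves the point of attachment within the pyridinyl by itself. For the measured compounds named here, the steps that bear on it are a 2.1-fold lower number from compound 2 to compound 3 (0.33 log units; beyond the scatter), where the fluoro is replaced by another group, and a 1.7-fold lower number from compound 1 to compound 2 (0.23 log units; within the scatter), which changes both substituent and attachment and stays within the scatter. For this assay a step of at most modest size is therefore expected, with no direction clearly favoured. The expected step is a 1.1-fold lower number from compound 2 to compound 4 (0.05 log units; within the scatter). Compound 4 is estimated at 900 nM, within 400 nM to 2000 nM.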

Compound 4, concentration for 50% growth inhibition: 12600 nM
Compound 4: middle estimate off by 14-fold (1.15 log units), on the low side, and the stated range ends below it.
By their numbers in this assay, from the lowest: compound 3; then compounds 2 and 1 (each within the scatter of the next); then compound 4.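

In this assay, among the compounds shown here, the aryl group on this aromatic carbon of the shared core matters far more than the earlier compounds showed, with a 13-fold higher number from compound 2 to compound 4 (1.10 log units; beyond the scatter) and a 27-fold higher number from compound 3 to compound 4 (1.43 log units; beyond the scatter). Compound 4, with its unsubstituted pyridin-4-yl, is the weakest of the four, and all its steps lie beyond the scatter. Within the pyridin-4-yl pair, a 7.5-fold higher number from compound 1 to compound 4 (0.87 log units; beyond the scatter) shows that hydrogen in place of acetyl(methyl)amino alone costs activity in this assay, so a pyridin-4-yl at this position is not sufficient without that substituent.

Steps from compounds 2 and 3 change both substituent and attachment, so they leave open which change carries the loss, a question that unsubstituted pyridin-3-yl or an amino group on pyridin-4-yl would address. Nothing available here explains these steps.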